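The source may report more compounds than this note shows. Statements on the series, on what has been measured and on what is new or still open speak of the compounds shown alone.

In a functional assay on NCI-H460 cells (Homo sapiens) for inhibition, read by MTT assay, with a stated time of 24 h, tested at 100 ug/mL (a higher number here means more inhibition of growth at the concentration tested, a lower number less inhibition of growth), compound 1 `O=C(CCCCC(S)CCS)NO` gives 43.7%, whereas compound 2 `O=C(CCCCC(S)CCS)Nc1ccccn1` gives 11.7%, the lower of the two numbers, since a number 32 percentage points lower from compound 1 to compound 2 (beyond the scatter). Compound 3 `O=C(CCCCC(S)CCS)Nc1ccc(Br)cn1` differs from compound 2 by bromo in place of hydrogen on an aromatic carbon. Within the data shown here, no measured step touches this position on the aromatic ring; the single known step, from hydroxy to pyridin-2-yl, concerns a different part of the molecule and offers no guidance here. Compound 3 is therefore expected to stay within the scatter of compound 2, a step of a number 4.3 percentage points higher from compound 2 to compound 3 (within the scatter), giving an estimate of 16% with a range from 5% to 35%.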

Compound 3, percent growth inhibition at one concentration: 55.9%
Estimate against measurement, compound 3: 39.9 percentage points below; the whole stated range lies below it.
By their numbers in this assay, from the lowest: compound 2; then compound 1; then compound 3.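

In this assay, the aromatic ring of the pyridin-2-yl amide turns out to be a strongly responsive site: bromo in place of hydrogen, two atoms from the ring nitrogen and para to a large group, gives a number 44.2 percentage points higher from compound 2 to compound 3 (beyond the scatter). Until now, the only step shown had been at the amide-type nitrogen, so this is the first sign that a single heavy atom on the ring can change the read-out this much. Nothing available explains this gain. The compounds shown leave open whether it is particular to bromo or would also come with chloro, methyl or an amine on the same aromatic carbon.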